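From acetyl to tert-butyl: an open step

The compounds below may be only part of what the source reports. "The series", "measured", "known", "first", "only" and "open" are said of these compounds alone.

Compound 1 `CC(=O)c1ccc(OCCCCN2CCN(c3cccnc3)CC2)cc1`: 69 nM
Compound 2 `CC(=O)c1ccc(OCCCCN2CCN(c3ccccn3)CC2)cc1`: 63.7 nM

Both numbers come from a functional assay on L5178Y cells (Mus musculus) for cytotoxicity, read by MTT assay; a lower number here means a stronger inhibitor, a higher number a weaker inhibitor. They cannot be told apart: a 1.1-fold lower number from compound 1 to compound 2 (0.03 log units; within the scatter). Among the measured compounds shown here, compound 1 therefore stands level with its only measured neighbour.

Compound 3 `CC(C)(C)c1ccc(OCCCCN2CCN(c3cccnc3)CC2)cc1` keeps the core of compound 1 but carries tert-butyl in place of acetyl on an aromatic carbon, para to a large group (tert-butyl in place of acetyl on an aromatic carbon). For the measured compounds named here, the only measured step, pyridin-2-yl in place of pyridin-3-yl on an amine nitrogen in a ring, lies in a different place. Going by the values given here, no measured step touches the acetyl group, so the data give no direction for this change, and the expectation stays close to the starting number with a wide margin.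

Among the compounds with values here, the expected change is a 1.2-fold lower number from compound 1 to compound 3 (0.06 log units; within the scatter), with no step expected beyond the scatter.

For compound 3 the estimated value is 60 nM, within an expected range of 15 nM to 240 nM.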

Compound 3, half-maximal inhibitory concentration: 11.7 nM
Compound 3: the middle estimate sits 5.1-fold (0.71 log units) above what was measured; measured number below the stated range.
By their numbers in this assay, from the lowest: compound 3; then compounds 2 and 1 (each within the scatter of the next).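

In this assay, among the compounds shown here, the group on this aromatic carbon, para to a large group, clearly matters: tert-butyl in place of acetyl gives a 5.9-fold lower number from compound 1 to compound 3 (0.77 log units; beyond the scatter) and so goes beyond the scatter, unlike the only earlier step, which changed the pyridine attachment on the amine nitrogen. The swap removes a double bond and a hydrogen-bond acceptor and leaves a group of carbon alone, but a single step cannot show which of these differences counts, or whether size plays any part. Nothing measured here explains the drop in the number.

Still open, on these data alone, is whether tert-butyl would have the same effect on the core of compound 2, which carries pyridin-2-yl. Also open, as far as these compounds go, is where other groups on this carbon would fall, such as isopropyl, methoxy, trifluoromethyl or a carboxylic acid.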